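A Methoxymethyl Amide Tried Against an Inactive Series

The source may report more compounds than this note shows. Statements on the series, on what has been measured and on what is new or still open speak of the compounds shown alone.

Compound 3 `O=C(Nc1cccc(NC(=O)c2cccc(Cl)c2)c1)c1ccc(Cl)cc1` stands at the limit of an in vitro functional assay on HEK293-A cells for antagonist activity at metabotropic glutamate receptor 5 (Rattus norvegicus), read by calcium flux; a higher number here means a weaker inhibitor, a lower number a stronger inhibitor: compound 3 gives > 30000 nM, a limit rather than a measured number. Compound 1 `COc1ccccc1C(=O)Nc1cccc(NC(=O)c2ccc(Cl)cc2)c1` likewise gives > 30000 nM, also a limit. Compound 2 `COc1ccccc1C(=O)Nc1cccc(NC(=O)c2ccco2)c1` gives > 30000 nM, again a limit. Compound 4 `COCC(=O)Nc1cccc(NC(=O)c2cccc(Cl)c2)c1` differs from compound 3 by methoxymethyl in place of 4-chlorophenyl on a carbonyl carbon. The measured steps do not touch this group: a step that the two limits leave unreadable from compound 1 to compound 2 and a step that the two limits leave unreadable from compound 1 to compound 3 both end at the limit, as the limit of > 30000 nM in this assay, at which 3 of the 3 values shown sit, records. For the measured compounds named here, no step in this assay has been readable, so no direction can be drawn from them; the step that the limit leaves unreadable from compound 3 to compound 4 is expected to stay within the scatter. Compound 4 is therefore expected to give 40000 nM, within 15000 nM to 100000 nM, most likely reported as a limit again.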

Compound 4, half-maximal inhibitory concentration: > 30000 nM
Compound 4 gave a limit, no number; the forecaster's own chance of this, stated with the estimate: 85%; the middle value lies beyond the limit too.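

No step can be read from compound 3 to compound 4, as both stand at the same limit: the limit of > 30000 nM in this assay, at which 4 of the 4 values shown sit.

The compounds shown leave open which change to the shared core, if any, would give a measurable value in this assay.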